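The compounds below may be only part of what the source reports. "The series", "measured", "known", "first", "only" and "open" are said of these compounds alone.

Compound 1 `COc1ccc(-c2nnc(-c3c[nH]c4ccccc34)o2)cc1` — in a functional assay on MCF7 cells (Homo sapiens) for cytotoxicity, read by MTT assay (on this read-out higher numbers stand for weaker inhibition and lower numbers for stronger inhibition), compound 1 gives > 1000000 nM, which is a limit of the assay and not a number.
Compound 2 `COc1ccc(-c2nnc(-c3c[nH]c4ccccc34)o2)cc1OC` — in this assay compound 2 gives 557000 nM.

Going by the values given here, compound 2 stands as the only compound with an actual number in this assay; the other value is a limit. Among the compounds with values here, the single measured step is an at least 1.7-fold lower number from compound 1 to compound 2 (0.25 log units; that floor lies within the scatter), a methoxy added on an aromatic carbon, and its floor comes from the limit of > 1000000 nM in this assay, at which 1 of the 2 values shown sits, so that step does not reach beyond the scatter.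

Compound 3 `COc1cc(-c2nnc(-c3c[nH]c4ccccc34)o2)ccc1OCc1ccccc1` carries phenyl in place of hydrogen on a saturated chain carbon bound to an oxygen on an aromatic ring. Within the data shown here, no measured step touches the group on this oxygen, so this change has no direct precedent; the only related step, an at least 1.7-fold lower number from compound 1 to compound 2 (0.25 log units; that floor lies within the scatter), was small and within the scatter. The step into compound 3 is therefore expected to be modest, at most a shift toward stronger inhibition, namely a 2.8-fold lower number from compound 2 to compound 3 (0.44 log units; beyond the scatter). Compound 3 is estimated at 200000 nM in this assay, with a range from 50000 nM to 800000 nM.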

Compound 3, half-maximal inhibitory concentration: > 1000000 nM
Compound 3 gave a limit, no number; the forecaster's own chance of this, stated with the estimate: 15%; at least 5.0-fold (0.69 log units) between middle value and limit.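

In this assay, the change from methoxy to benzyloxy reads as an at least 1.7-fold higher number from compound 2 to compound 3 (0.25 log units; that floor lies within the scatter), so only a floor is known and that floor does not separate the two compounds. Going by these compounds alone, this is the first change at the group on this oxygen, and phenyl on a saturated chain carbon bound to an oxygen on an aromatic ring brings no sign of stronger inhibition. The result also leaves compound 2 as the only compound with an actual number, and the size of the step stays capped by the limit: the limit of > 1000000 nM in this assay, at which 2 of the 3 values shown sit.

From the compounds shown here alone, how far compound 3 really lies from compound 2 stays open. Also open, going by these compounds, is what an amine, a carboxylic acid or a longer chain in place of the phenyl on this chain would do in this assay.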